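Amide chain swap on the shared core: propyl to isopropylamino

This account rests on a few compounds, and the source may have more. Where it says the series, first, only, none or still open, it means among the compounds named here.

Compound 1 `CCCCC(=O)NCC(=O)N(C)c1ccc(Cl)cc1C(=O)c1ccccc1Cl` is measured in a functional assay on the whole organism for antagonist activity, with Mus musculus as the target (on this read-out lower numbers stand for an effect already at smaller amounts and higher numbers for an effect only at larger amounts of compound), at 1.3 mg/kg, the lowest of the two numbers obtained so far. Compound 2 `NCC(=O)NCC(=O)Nc1ccc([N+](=O)[O-])cc1C(=O)c1ccccc1` gives in this assay a value of 4.82 mg/kg, a step beyond the scatter relative to compound 1. Compound 3 `CC(=O)NCC(=O)Nc1ccc(Cl)cc1C(=O)c1ccccc1Cl` yields only > 100 mg/kg in this assay, which is a limit of the assay rather than a number (the limit of > 100 mg/kg in this assay, at which 1 of the 3 values shown sits).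

Compound 4 `CC(C)NCC(=O)NCC(=O)N(C)c1ccc(Cl)cc1C(=O)c1ccccc1Cl` is not yet measured. It differs from compound 1 in one place: isopropylamino in place of propyl on a saturated chain carbon bound to a carbonyl carbon. For the measured compounds named here, no measured pair in the set shares this change, so the direction must be read from compound 2, whose chain also carries an amine and gives 4.82 mg/kg in this assay.

Compound 4 is expected to remain near compound 1, with a step of a 1.9-fold higher number from compound 1 to compound 4 (0.28 log units; within the scatter) that is small and may lie within the scatter. The estimate for compound 4 in this assay is 2.5 mg/kg, with a range from 0.8 mg/kg to 8 mg/kg.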

Compound 4, dose for half-maximal effect: 1 mg/kg
For compound 4 the middle estimate is 2.5-fold (0.40 log units) above the measured one; measured number inside the range.
By their numbers in this assay, from the lowest: compounds 4 and 1 (each within the scatter of the next); then compound 2. At a limit, above all of these: compound 3.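

In this assay the change to isopropylamino gives a 1.3-fold lower number from compound 1 to compound 4 (0.11 log units; within the scatter), so on this saturated chain carbon bound to a carbonyl carbon, the propyl and isopropylamino compounds stand level. For the compounds shown here, compound 2 also carries an amine on its chain but differs from compound 1 in more than one place, so this pair is the first to isolate the change at this position. Nothing in the data shown accounts for this step.

From the compounds shown here alone, compound 3 gives > 100 mg/kg in this assay, which is a limit of the assay and not a number, and it differs from compound 1 in more than one place, so what separates the two stays open. Also open, going by these compounds, is how a carboxylic acid or a piperidine would read at this position, where the direct comparison covers only propyl and isopropylamino.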